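The source may report more compounds than this note shows. Statements on the series, on what has been measured and on what is new or still open speak of the compounds shown alone.

Compound 1 `Cc1noc(C)c1-c1nn(Cc2ccc(C(=O)NC3CC(C)(C)N([O])C(C)(C)C3)cc2)c(=O)c2ccccc12` gives 85100 nM in a functional assay on HepG2 cells (Homo sapiens) for antiproliferative activity, read by MTT assay, with a stated time of 72 h; on this read-out lower numbers stand for stronger inhibition and higher numbers for weaker inhibition. Compound 2 `Cc1noc(C)c1-c1nn(Cc2ccc(C(=O)NC3CCN(C)CC3)cc2)c(=O)c2ccccc12` reaches only a limit in this assay, > 100000 nM. Compound 3 `CC(=O)Nc1ccc(Sc2nc(Nc3cc(C)[nH]n3)cc(N3CCN(C)CC3)n2)cc1` gives 13700 nM in this assay.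

Compound 1 thus holds the highest of the two numbers; compound 3 sits lower, beyond the scatter. Compound 4 `Cn1cc(-c2nn(Cc3ccc(C(=O)NC4CC(C)(C)N([O])C(C)(C)C4)cc3)c(=O)c3ccccc23)cn1` differs from compound 1 by 1-methyl-1H-pyrazol-4-yl in place of 3,5-dimethyl-1,2-oxazol-4-yl on an aromatic carbon. Among the compounds with values here, the one measured step, an at least 1.1-fold higher number from compound 1 to compound 2 (0.07 log units; that floor lies within the scatter), concerns the group on the amide-type nitrogen and ends at a limit (the limit of > 100000 nM in this assay, at which 1 of the 3 values shown sits), so no measured step touches the aromatic carbon that changes here. For compound 4 no step beyond the scatter is expected, and compound 4 is estimated at 80000 nM, ranging from 30000 nM to 200000 nM. The expected step of a 1.1-fold lower number from compound 1 to compound 4 (0.03 log units; within the scatter) would stay within the usual scatter.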

Compound 4, half-maximal inhibitory concentration: 27400 nM
For compound 4 the middle estimate is 2.9-fold (0.47 log units) above the measured one, and the stated range ends above it.
By their numbers in this assay, from the lowest: compounds 3 and 4 (each within the scatter of the next); then compound 1. At a limit, above all of these: compound 2.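

Putting 1-methyl-1H-pyrazol-4-yl in place of 3,5-dimethyl-1,2-oxazol-4-yl gives a 3.1-fold lower number from compound 1 to compound 4 (0.49 log units; beyond the scatter) in this assay, so this aromatic carbon now has a measured step, and it lies beyond the scatter. The two groups have the same counts of hydrogen-bond donors and acceptors and no net charge, so those counts do not separate them. The step to compound 2, on the amide-type nitrogen, ends at a limit and gives no size to compare: the limit of > 100000 nM in this assay, at which 1 of the 4 values shown sits.

From the compounds shown here alone, it remains open whether an amine or a carboxylic acid at this aromatic carbon would shift the number further. Going by these compounds, it is also open whether the step would hold with the group of compound 2 on the amide-type nitrogen.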